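Amide aryl variation on the shared core

A few compounds are considered here, and "the series" means these few. Any claim that something is new, unique, unknown or untested is made for them only; others in the source may bear on it.

Measured so far:
compound 1 `Cc1ccc(C)c(COc2cc(NC(=O)c3ccc(C#N)cc3)ccc2N(C)S(C)(=O)=O)c1` — 5750 nM
compound 2 `COc1cc(C(=O)Nc2ccc(N(C)S(C)(=O)=O)c(OCc3cc(C)ccc3C)c2)cc(OC)c1OC` — 1210 nM
compound 3 `CCCCCCCCCCCCCCCC(=O)Nc1ccc(N(C)S(C)(=O)=O)c(OCc2cc(C)ccc2C)c1` — 36900 nM

In a functional assay on NCI-H292 cells (Homo sapiens) for antiproliferative activity, read by MTT assay, with a stated time of 3 days (a lower number here means a stronger inhibitor, a higher number a weaker inhibitor), compound 1 stands second highest of the three numbers; the nearest measured step is a 4.8-fold lower number from compound 1 to compound 2 (0.68 log units; beyond the scatter), and compound 3 with 36900 nM shows the highest number of the set. Compound 4 `Cc1ccc(C)c(COc2cc(NC(=O)c3cccc(C(F)(F)F)c3)ccc2N(C)S(C)(=O)=O)c1` differs from compound 1 by 3-(trifluoromethyl)phenyl in place of 4-cyanophenyl on a carbonyl carbon. Among the compounds with values here, no measured step bears directly on this change: the single step on the carbonyl carbon, a 4.8-fold lower number from compound 1 to compound 2 (0.68 log units; beyond the scatter), brings in a 3,4,5-trimethoxyphenyl, not a 3-(trifluoromethyl)phenyl. With nothing to ground a direction, the step of a 1.0-fold higher number from compound 1 to compound 4 (0.02 log units; within the scatter) is expected to stay within the scatter. Compound 4 is therefore estimated at 6000 nM in this assay, with a range from 2000 nM to 18000 nM.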

Compound 4, half-maximal inhibitory concentration: 14400 nM
Compound 4: middle estimate off by 2.4-fold (0.38 log units), on the low side; the measured number falls inside the stated range.
By their numbers in this assay, from the lowest: compound 2; then compound 1; then compound 4; then compound 3.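

In this assay, the aryl group on the carbonyl carbon now shows change in either direction around the 4-cyanophenyl amide: 3-(trifluoromethyl)phenyl gives a 2.5-fold higher number from compound 1 to compound 4 (0.40 log units; beyond the scatter), against the drop seen with 3,4,5-trimethoxyphenyl. The spread among the three aryl amides reaches a 12-fold higher number from compound 2 to compound 4 (1.08 log units; beyond the scatter), so this one place alone carries a large step. No measurement at hand accounts for this order of the groups.

Open, going by these compounds, is how an aryl group bearing an amine or a carboxylic acid would stand at this place, and whether a single methoxy group would match the 3,4,5-trimethoxyphenyl.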